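Solubility notes on the step to compound 4

The source may hold more compounds than are shown below. What is called first, only, known or untested is meant among the compounds shown, and "the series" means these compounds.

compound 1 `Cc1cc(S(=O)(=O)NCCCC[C@@H](Nc2cc(C)c(F)c(C)c2)C(=O)NO)ccc1F`: > 5 ug/mL
compound 2 `Cc1cc(CNCCCC[C@@H](Nc2cc(C)c(F)c(C)c2)C(=O)NO)ccc1F`: > 5 ug/mL
compound 3 `Cc1cc(NC(=O)NCCCC[C@@H](Nc2cc(C)c(F)c(C)c2)C(=O)NO)ccc1F`: > 5 ug/mL

In a physicochemical assay for solubility, in phosphate buffer (a higher number here means a more soluble compound, a lower number a less soluble compound), compound 2 gives > 5 ug/mL, which is a limit and not a number. The whole set reads the same way, with the limit of > 5 ug/mL in this assay, at which 3 of the 3 values shown sit. Among the compounds with values here, compound 2 therefore cannot be ranked against compound 1 or compound 3, and no measured pair isolates a single change.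

Compound 4 `Cc1cc(N[C@H](CCCCNCc2cccc(F)c2)C(=O)NO)cc(C)c1F` differs from compound 2 in one place: 3-fluorophenyl in place of 4-fluoro-3-methylphenyl on a saturated chain carbon bound to an amine nitrogen. It carries 3-fluorophenyl in place of 4-fluoro-3-methylphenyl on a saturated chain carbon bound to an amine nitrogen.

No step beyond the scatter is expected in this assay, in either direction. The estimated change is a step that the limit leaves unreadable from compound 2 to compound 4. This expectation rests on compound 2, whose reading of > 5 ug/mL is only a limit. Another report as a limit is the likeliest outcome. For compound 4 the estimated solubility is 7 ug/mL, with an expected range from 4 ug/mL to 25 ug/mL.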

Compound 4, solubility: > 5 ug/mL
Compound 4: a limit, no number; the forecaster's own chance of this, stated with the estimate: 70%; the middle value is on the limit's open side.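

In this assay compound 4 gives > 5 ug/mL, which is a limit and not a number. No step between compound 2 and compound 4 can be read, because both readings rest on the same limit: the limit of > 5 ug/mL in this assay, at which 4 of the 4 values shown sit.

The compounds shown leave open how these four compounds rank in solubility.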